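The compounds below may be only part of what the source reports. "The series", "measured", "known", "first", "only" and "open" are said of these compounds alone.

Compound 1 `COc1ccc(-c2ccc3ncn(-c4cc(OC)c(OC)c(OC)c4)c3c2)cc1O` carries a trisubstituted aromatic ring on one side of its shared core and a 3-hydroxy-4-methoxyphenyl group on the other. In a functional assay on A549 cells (Homo sapiens) for antiproliferative activity, read by MTT assay, with a stated time of 72 h (a lower number here means a stronger inhibitor, a higher number a weaker inhibitor), compound 1 gives 200 nM, the lowest number among the three compounds measured, so it is the strongest inhibitor of the set. Compound 2 `COc1cc(-n2cnc3ccc(-c4cc(F)ccc4F)cc32)cc(OC)c1OC` keeps everything else but swaps that group for 2,5-difluorophenyl; in this assay compound 2 gives 7940 nM. Compound 3 `COc1cc(-n2cnc3ccc(-c4cccc(C)c4)cc32)cc(OC)c1OC` carries 3-methylphenyl instead, and compound 3 gives 3820 nM. The steps tell the story: a 40-fold higher number from compound 1 to compound 2 (1.60 log units; beyond the scatter) and a 19-fold higher number from compound 1 to compound 3 (1.28 log units; beyond the scatter), while a 2.1-fold lower number from compound 2 to compound 3 (0.32 log units; beyond the scatter). Both replacements of the 3-hydroxy-4-methoxyphenyl group thus weakened inhibition strongly.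

Compound 4 `COc1cc(-n2cnc3ccc(-c4ccc(Cl)cc4Cl)cc32)cc(OC)c1OC` has not yet been measured. Its change from compound 1 is 2,4-dichlorophenyl in place of 3-hydroxy-4-methoxyphenyl on an aromatic carbon. The entering group, like the 2,5-difluorophenyl of compound 2, has no hydrogen-bond donor or acceptor, so the step from compound 1 to compound 2 is the closest guide, and the step to compound 3 points the same way. A large rise in the number is therefore expected, estimated as a 30-fold higher number from compound 1 to compound 4 (1.48 log units; beyond the scatter). Compound 4 is expected to give 6000 nM, with a likely range from 2000 nM to 20000 nM.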

Compound 4, half-maximal inhibitory concentration: > 10000 nM
Compound 4: no number, only a limit (the forecaster's own chance of this, stated with the estimate: 10%); middle value at least 1.6-fold (0.22 log units) from the limit.
By their numbers in this assay, from the lowest: compound 1; then compound 3; then compound 2. At a limit, above all of these: compound 4.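

In this assay compound 4 gives > 10000 nM, which is a limit of the assay and not a number. With 2,4-dichlorophenyl on this aromatic carbon the result is an at least 50-fold higher number from compound 1 to compound 4 (1.69 log units; beyond the scatter), so a third replacement of the 3-hydroxy-4-methoxyphenyl group, and the first to carry chlorine, also loses far more than the scatter allows, and all three replacements shown lack the hydrogen-bond donor and acceptors of the group they replace. The limit also sets compound 4 apart from the 3-methylphenyl analogue, with an at least 2.6-fold higher number from compound 3 to compound 4 (0.41 log units; beyond the scatter), whereas an at least 1.2-fold higher number from compound 2 to compound 4 (0.10 log units; that floor lies within the scatter) does not separate it, so compound 2 and compound 4 cannot be put in order.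

As far as these compounds go, whether a phenyl ring with the hydroxy group alone, the methoxy group alone, or an amine in place of the hydroxy group would keep the number close to that of compound 1 remains open. Also open, from the compounds shown here alone, is whether any ring without a hydrogen-bond donor could come close to compound 1 at this position.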